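Chain extension on the methoxymethyl ether of compound 3

A few compounds are considered here, and "the series" means these few. Any claim that something is new, unique, unknown or untested is made for them only; others in the source may bear on it.

Measured compounds:
compound 1 `Nc1ccc(-c2cc(=O)c3c(N)c(F)c(C(=O)O)c(F)c3o2)cc1F` — > 10000 nM
compound 2 `CN(C)CC(=O)OCc1c(F)c(N)c2c(=O)cc(-c3ccc(N)c(F)c3)oc2c1F` — 26 nM
compound 3 `COCc1c(F)c(N)c2c(=O)cc(-c3ccc(N)c(F)c3)oc2c1F` — 46 nM

In a functional assay on MCF7 cells (Homo sapiens) for cytotoxicity, read by neutral red uptake, with a stated time of 3 days (on this read-out higher numbers stand for weaker inhibition and lower numbers for stronger inhibition), compound 1 gives only a limit, > 10000 nM (the limit of > 10000 nM in this assay, at which 1 of the 3 values shown sits). Compound 3 sits with compound 2 inside the usual scatter: a 1.8-fold higher number from compound 2 to compound 3 (0.25 log units; within the scatter). Both carbon-linked replacements of the carboxy group gave large steps, an at least 380-fold lower number from compound 1 to compound 2 (2.58 log units; beyond the scatter) and an at least 210-fold lower number from compound 1 to compound 3 (2.33 log units; beyond the scatter).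

Compound 4 `CN(C)CCCOCc1c(F)c(N)c2c(=O)cc(-c3ccc(N)c(F)c3)oc2c1F` carries 2-(dimethylamino)ethyl in place of hydrogen on a saturated chain carbon bound to an oxygen on a saturated carbon. Within the data shown here, the only step that bears on it is the exchange at the same oxygen, a 1.8-fold higher number from compound 2 to compound 3 (0.25 log units; within the scatter), where a bulkier group with a dimethylamino nitrogen and a methyl gave the same result within scatter. No step beyond the scatter is therefore expected for a 1.2-fold lower number from compound 3 to compound 4 (0.06 log units; within the scatter). Compound 4 is estimated at 40 nM, in the range 15 nM to 120 nM.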

Compound 4, half-maximal inhibitory concentration: > 10000 nM
Compound 4 ended at the assay's limit; the forecaster's own chance of this, stated with the estimate: 3%; middle value at least 250-fold (2.39 log units) away from the limit.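

A dimethylamino-bearing chain on this oxygen is not interchangeable with methyl: 3-(dimethylamino)propyl gives an at least 210-fold higher number from compound 3 to compound 4 (2.33 log units; beyond the scatter). The same chain against the ester of compound 2 gives an at least 380-fold higher number from compound 2 to compound 4 (2.58 log units; beyond the scatter), so the dimethylamino nitrogen alone does not set the outcome, as compound 2 carries one too. Compound 4 gives only a limit, as does compound 1, so the step between them cannot be read: the limit of > 10000 nM in this assay, at which 2 of the 4 values shown sit.

Still open, as far as these compounds go, is whether the ester carbonyl, the chain length or the terminal amine separates compound 2 from compound 4. A 2-(dimethylamino)ethyl ether or a plain propyl ether on the same oxygen would bear on this.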